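The source may report more compounds than this note shows. Statements on the series, on what has been measured and on what is new or still open speak of the compounds shown alone.

Compound 1, with structure `O=Cc1cccc(OCc2cn(Cc3ccccc3)nn2)c1`, was tested in a functional assay on DU-145 cells (Homo sapiens) for inhibition, read by MTT assay, with a stated time of 48 h (on this read-out lower numbers stand for stronger inhibition and higher numbers for weaker inhibition), and gives only > 50000 nM, which is a limit of the assay rather than a number. Compound 2, with structure `O=C1Nc2ccc(Cl)cc2/C1=C/c1cccc(OCc2cn(Cc3ccccc3)nn2)c1`, gives 24200 nM in this assay. Going by the values given here, compound 2 therefore holds the only actual number here; the other entry is the limit of > 50000 nM in this assay, at which 1 of the 2 values shown sits, belonging to compound 1. Compound 3, with structure `O=C1Nc2ccc(Br)cc2/C1=C/c1cccc(OCc2cn(Cc3ccccc3)nn2)c1`, differs from compound 2 by bromo in place of chloro on an aromatic carbon. Among the compounds with values here, no measured pair shows this swap, so the expected step from compound 2 to compound 3 is a 1.2-fold lower number from compound 2 to compound 3 (0.08 log units; within the scatter), within the scatter. Compound 3 is estimated at 20000 nM, between 8000 nM and 50000 nM.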

Compound 3, half-maximal inhibitory concentration: 35100 nM
Beside the measured number, compound 3's estimate is 1.8-fold (0.24 log units) below it; the measured number falls inside the stated range.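

In this assay, putting bromo in place of chloro on this aromatic carbon gives a 1.5-fold higher number from compound 2 to compound 3 (0.16 log units; within the scatter). Going by these compounds alone, this is the first measured pair to show a change at this position, and with these two halogens the read-out does not separate compound 2 from compound 3. Nothing measured here accounts for the size of this step.

Going by these compounds, what remains open is whether a quite different group on the same carbon, such as an amine or a carboxylic acid, would shift the number beyond the usual scatter.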